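This account rests on a few compounds, and the source may have more. Where it says the series, first, only, none or still open, it means among the compounds named here.

Two compounds share one core and differ only in the group carried on the benzyl ring of the triazole side chain. Compound 1 `O=C(NCc1cn(Cc2ccc(F)cc2)nn1)c1cn(-c2ccccc2)nc1-c1ccccc1` carries a fluoro there and, in a functional assay on MIA PaCa-2 cells (Homo sapiens) for antiproliferative activity, read by sulforhodamine B assay, with a stated time of 48 h (a lower number here means a stronger inhibitor of growth, a higher number a weaker inhibitor of growth), compound 1 gives 9600 nM. Compound 2 `O=C(NCc1cn(Cc2ccc(Cl)cc2)nn1)c1cn(-c2ccccc2)nc1-c1ccccc1` carries a chloro in the same place and, in this assay, compound 2 gives 8700 nM. For the measured compounds named here, the single step between them, a 1.1-fold lower number from compound 1 to compound 2 (0.04 log units; within the scatter), shows that swapping one halogen for another on that aromatic carbon left the growth inhibition unchanged within the scatter, so compound 2 and compound 1 stand together rather than apart.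

Compound 3 `O=C(NCc1cn(Cc2ccc(C(F)(F)F)cc2)nn1)c1cn(-c2ccccc2)nc1-c1ccccc1` continues along the same carbon: trifluoromethyl in place of chloro on an aromatic carbon. Going by the values given here, the only measured step that speaks to this position is the fluoro-to-chloro exchange, and it was within the scatter. Nothing measured suggests that a third substituent of this kind at the same place should move the number much, though the trifluoromethyl is a larger group than either halogen. Compound 3 is therefore expected to give about 8500 nM in this assay, between 3500 nM and 20000 nM, meaning an expected step of a 1.0-fold lower number from compound 2 to compound 3 (0.01 log units; within the scatter).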

Compound 3, concentration for 50% growth inhibition: 17700 nM
Compound 3: the middle estimate sits 2.1-fold (0.32 log units) below what was measured; the measured number falls inside the stated range.
By their numbers in this assay, from the lowest: compounds 2, 1 and 3 (each within the scatter of the next, the first and the last beyond it).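

In this assay, for the compounds shown here, the change from chloro to trifluoromethyl gives a 2.0-fold higher number from compound 2 to compound 3 (0.31 log units; beyond the scatter) and is the first step at this position to lie beyond the scatter, so the position is not wholly indifferent to the group it carries, although the step is modest. The same group set against fluoro gives a 1.8-fold higher number from compound 1 to compound 3 (0.27 log units; within the scatter) and stays within the scatter, so the difference shows up against only one of the two halogens, and compound 3 cannot be set apart from compound 1. The change swaps one heavy atom for four, with no hydrogen-bond donors or acceptors on either side, but nothing at hand explains why the number moved.

All three compounds carry a halogen or trifluoromethyl at this position, which leaves open how the number would respond to an amine, a carboxylic acid, a methoxy group or a longer chain there. As far as these compounds go, it also remains open whether changes elsewhere on the shared core could move the number further than any change at this position has.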